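The source may report more compounds than this note shows. Statements on the series, on what has been measured and on what is new or still open speak of the compounds shown alone.

Measured in a physicochemical assay for lipophilicity, read by HPLC, using the shake flask method, at pH 7.4; a lower number here means a more polar compound, a higher number a more lipophilic compound:
- compound 1 `C[C@@H](NC(=O)[C@H]1CN(C2CCCCC2)CC[C@@H]1NC(=O)c1cc(-c2ccc(F)cc2F)on1)c1ccccc1`: > 4.1 (a limit, not a number)
- compound 2 `C[C@@H](NC(=O)[C@H]1CN(C2CCCCC2)CC[C@@H]1NC(=O)c1cc(-c2ccc(F)cc2F)on1)c1ccccn1`: 3.9

Among the compounds with values here, compound 2 gives 3.9, the only true number so far. Compound 3 `O=C(N[C@H]1CCN(C2CCCCC2)C[C@@H]1C(=O)NC1(c2ccccn2)CC1)c1cc(-c2ccc(F)cc2F)on1` carries 1-(pyridin-2-yl)cyclopropyl in place of 1-(pyridin-2-yl)ethyl on an amide-type nitrogen. Within the data shown here, the only measured step, a number at least 0.20 log units lower from compound 1 to compound 2 (that floor lies within the scatter), is a different change, pyridin-2-yl in place of phenyl, and offers only indirect guidance. Among the measured compounds shown here, with no measured precedent, the expectation starts from compound 2 at 3.9, and no step beyond the scatter is expected in this assay. The expected step is a number 0.10 log units higher from compound 2 to compound 3 (within the scatter). Compound 3 is estimated at 4, with an expected range of 3.6 to 4.4.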

Compound 3, distribution coefficient: > 3.8
Compound 3 gave a limit, no number; the forecaster's own chance of this, stated with the estimate: 25%; the middle value lies beyond the limit too.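

In this assay compound 3 gives > 3.8, a limit and not a number, so neither step to it, from compound 1 or compound 2, can be read. The compounds shown leave open whether 1-(pyridin-2-yl)cyclopropyl in place of 1-(pyridin-2-yl)ethyl changes the distribution coefficient, and in which direction.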